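A Longer Alkene Chain on an Amide Without Measurable Potency

The source may report more compounds than this note shows. Statements on the series, on what has been measured and on what is new or still open speak of the compounds shown alone.

Compound 1 `C=CC(=O)Nc1cccc(Nc2ncnc3ccc(-c4ccc(Cl)nc4)cc23)c1` and compound 2 `C=CC(=O)Nc1cccc(Nc2ncnc3ccc(-c4cnc5ccccc5c4)cc23)c1` share a common core and differ only in the ring attached to it. In a functional assay on Ramos cells (Homo sapiens) for inhibition, read by MTT assay, with a stated time of 48 h (a higher number here means a weaker inhibitor, a lower number a stronger inhibitor), compound 1 gives "not determined" (no result reported). In this assay compound 2 gives > 50000 nM, which is a limit of the measurement rather than a number. All that is known of compound 2, therefore, is that its potency lies outside the range the measurement can report.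

Compound 3 `C/C=C/C(=O)Nc1cccc(Nc2ncnc3ccc(-c4cnc5ccccc5c4)cc23)c1` is derived from compound 2 by a single change: prop-1-en-1-yl in place of vinyl on a carbonyl carbon. Within the data shown here, no measured pair shows what this change does. Compound 2 already stands at the limit of > 50000 nM in this assay, at which 1 of the 2 values shown sits, and the step to compound 3 is expected to be none beyond the scatter, most likely ending at the same limit. The estimated value for compound 3 in this assay is 50000 nM, with a range from 20000 nM to 120000 nM. The step expected here is a number no higher from compound 2 to compound 3 (the limit leaves the size open).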

Compound 3, half-maximal inhibitory concentration: 5000 nM
Estimate against measurement, compound 3: 10-fold (1.00 log units) above; measured number outside the range, below it.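

Prop-1-en-1-yl in place of vinyl on a carbonyl carbon gives an at least 10-fold lower number from compound 2 to compound 3 (1.00 log units; beyond the scatter) in this assay, so this position responds to a small change in the chain. Compound 3 is the only compound shown with a single number, which puts the series inside the range that the measurement can report. The full size of the step stays open because its starting point is a limit and not a number: the limit of > 50000 nM in this assay, at which 1 of the 3 values shown sits.

Among these compounds, compound 1 has no result, so no step involving it can be read, and whether the same change would matter alongside its ring remains unknown. As far as these compounds go, it is also open whether a longer chain on the alkene, such as a butenyl group, or a dimethylamine at the end of the chain would give a lower number than compound 3.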